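Swapping the para nitro for trifluoromethyl on compound 2

The source may hold more compounds than are shown below. What is called first, only, known or untested is meant among the compounds shown, and "the series" means these compounds.

Measured so far:
compound 1, `O=C(CSc1nc(Nc2ccccc2)c2ccccc2n1)Nc1ccccc1F`: > 50000 nM
compound 2, `O=C(CSc1nc(Nc2ccccc2)c2ccccc2n1)Nc1ccc([N+](=O)[O-])cc1`: 16800 nM

In a functional assay on MDA-MB-231 cells (Homo sapiens) for inhibition, read by MTT assay, with a stated time of 72 h (on this read-out higher numbers stand for weaker inhibition and lower numbers for stronger inhibition), compound 1 gives only a limit, > 50000 nM, as the limit of > 50000 nM in this assay, at which 1 of the 2 values shown sits, records. For the measured compounds named here, compound 2 gives the sole number seen, 16800 nM. Going by the values given here, the one measured step, an at least 2.9-fold lower number from compound 1 to compound 2 (0.47 log units; beyond the scatter), concerns a different change of the anilide ring and offers no direct guide. Compound 3, `O=C(CSc1nc(Nc2ccccc2)c2ccccc2n1)Nc1ccc(C(F)(F)F)cc1`, differs from compound 2 by trifluoromethyl in place of nitro on an aromatic carbon. Without a precedent for this swap, a step no larger than the scatter is expected, a 1.3-fold higher number from compound 2 to compound 3 (0.12 log units; within the scatter). Compound 3 is therefore estimated at 22000 nM, between 7000 nM and 60000 nM.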

Compound 3, half-maximal inhibitory concentration: 11100 nM
Compound 3: the middle estimate sits 2.0-fold (0.30 log units) above what was measured; the range from low to high includes it.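

Compound 2 and compound 3 cannot be told apart in this assay (a 1.5-fold lower number from compound 2 to compound 3 (0.18 log units; within the scatter)), so at this aromatic carbon trifluoromethyl, with no hydrogen-bond acceptors, serves as well as nitro. The gap to the 2-fluorophenyl compound also appears with 4-(trifluoromethyl)phenyl (an at least 4.5-fold lower number from compound 1 to compound 3 (0.65 log units; beyond the scatter)), so it is not tied to nitro alone. Compound 1 remains a limit, and that step is only a bound: the limit of > 50000 nM in this assay, at which 1 of the 3 values shown sits. The compounds shown leave open how an amine or a carboxylic acid on this aromatic carbon would read. They also leave open whether fluorine itself or its place sets compound 1 apart.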